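Methylating the hydroxy group of compound 3

This account rests on a few compounds, and the source may have more. Where it says the series, first, only, none or still open, it means among the compounds named here.

Measured in a functional assay on HCT-116 cells (Homo sapiens) for antiproliferative activity, read by MTT assay, with a stated time of 96 h (on this read-out higher numbers stand for weaker inhibition and lower numbers for stronger inhibition), as follows:
- compound 1 `COc1c(O)cc2cc1C[C@H](C)C[C@H](OC)[C@H](O)[C@@H](C)/C=C(\C)C[C@H](OC(N)=O)[C@@H](OC)CC/C=C(\C)C(=O)N2` gives 1790 nM
- compound 2 `COc1ccc([C@H]2c3cccc(c3O)NC(=O)/C(C)=C/C=C\[C@H](OC)[C@@H](OC(N)=O)/C(C)=C/[C@H](C)[C@@H](O)[C@@H](OC)C[C@@H]2C)cc1` gives 440 nM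
- compound 3 `COc1ccc([C@H]2c3cccc(c3O)NC(=O)/C(C)=C/CC[C@H](OC)[C@@H](OC(N)=O)/C(C)=C/[C@H](C)[C@@H](O)[C@@H](OC)C[C@@H]2C)cc1` gives > 20000 nM as a limit of the assay

Compound 3 stands at the limit of > 20000 nM in this assay, at which 1 of the 3 values shown sits, and so has no number of its own. Compound 1 and compound 2 both return numbers, which leaves compound 3 as the only one of the three without one.

The next compound is compound 4 `COc1ccc([C@H]2c3cccc(c3O)NC(=O)/C(C)=C/CC[C@H](OC)[C@@H](OC(N)=O)/C(C)=C/[C@H](C)[C@@H](OC)[C@@H](OC)C[C@@H]2C)cc1`. The change from compound 3 is methyl in place of hydrogen on an oxygen on a saturated carbon and reads in words as methyl in place of hydrogen on an oxygen on a saturated carbon, hydroxy to methoxy. Going by the values given here, no measured pair shows this change. The expectation rests on compound 3 alone, whose > 20000 nM is a limit. No gain beyond the usual scatter is expected in this assay, and another result reported only as a limit is the likeliest outcome. The expected change is a number no higher from compound 3 to compound 4 (the limit leaves the size open) as an estimate. Compound 4 is estimated at 20000 nM with an expected range from 6000 nM to 50000 nM as the working figures.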

Compound 4, half-maximal inhibitory concentration: > 20000 nM
Compound 4: a limit, no number (the forecaster's own chance of this, stated with the estimate: 65%); the middle value sits exactly at the limit.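

Compound 3 and compound 4 both end at a limit of the assay, so no step can be read between them: the limit of > 20000 nM in this assay, at which 2 of the 4 values shown sit. The compounds shown leave open what hydroxy to methoxy at this place does to antiproliferative activity, in either direction.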